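This account rests on a few compounds, and the source may have more. Where it says the series, first, only, none or still open, it means among the compounds named here.

Within the data shown here, compound 2 `N#Cc1cccc(-c2nc(N)c3cc(CN4CCC(F)CC4)sc3n2)c1` gives 2950 nM in an assay on CHO-K1 cells for antagonist activity at adenosine receptor A1 (Homo sapiens), read by a beta-galactosidase reporter, with stated times of 15 min and 6 h (on this read-out lower numbers stand for stronger inhibition and higher numbers for weaker inhibition), the highest of the three numbers measured so far. Compound 1 `Nc1nc(-c2cc3ccccc3o2)nc2sc(CN3CCC(F)CC3)cc12` gives 630 nM in this assay, and compound 3 `C[C@@H]1CN(Cc2cc3c(N)nc(-c4cccc(C#N)c4)nc3s2)C[C@H](C)O1` gives 1070 nM. The step of a 4.7-fold higher number from compound 1 to compound 2 (0.67 log units; beyond the scatter) exchanges the whole aryl group on the shared core, and the step of a 2.8-fold lower number from compound 2 to compound 3 (0.44 log units; beyond the scatter) exchanges the amine on the saturated chain carbon. Compound 4 `CN(C)C(=O)c1cccc(-c2nc(N)c3cc(CN4CCC(F)CC4)sc3n2)c1` differs from compound 2 by dimethylcarbamoyl in place of cyano on an aromatic carbon. Among the measured compounds shown here, neither measured step bears directly on this change: both alter other parts of the molecule, and no measured pair varies a substituent on the six-membered aromatic ring of carbon only. Both measured steps were modest in size. For the measured compounds named here, with no closely related step to draw on, the change from compound 2 to compound 4 in this assay is expected to be a 1.0-fold higher number from compound 2 to compound 4 (0.01 log units; within the scatter), small and of uncertain direction. Compound 4 is therefore estimated at 3000 nM, with a range from 1000 nM to 9000 nM.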

Compound 4, inhibition constant: > 10000 nM
Compound 4: no number, only a limit (the forecaster's own chance of this, stated with the estimate: 5%); middle value at least 3.3-fold (0.52 log units) away from the limit.
By their numbers in this assay, from the lowest: compounds 1 and 3 (each within the scatter of the next); then compound 2. At a limit, above all of these: compound 4.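

Dimethylcarbamoyl in place of cyano, on the aromatic carbon meta to a large group, gives an at least 3.3-fold higher number from compound 2 to compound 4 (0.53 log units; beyond the scatter), so this position, which no earlier pair varied, is not indifferent to what it carries. Compound 4 has no number in this assay, only a limit: the limit of > 10000 nM in this assay, at which 1 of the 4 values shown sits. The exchange adds heavy atoms and a carbonyl while the counts of hydrogen-bond donors and acceptors stay as they were, so the step does not follow from a change in those counts.

The compounds shown leave open how far compound 4 lies beyond its limit, and whether the size of the entering group or its carbonyl accounts for the step. A plain methyl, a methoxy group or an unsubstituted carboxamide at this place would be needed to separate the two.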